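A few compounds are considered here, and "the series" means these few. Any claim that something is new, unique, unknown or untested is made for them only; others in the source may bear on it.

Of the compounds shown here, three of one series have been measured so far, and they differ in two places. Compound 2 `COc1ccc(-c2ccc3ncnc(NCCN4CCCC4)c3c2)cn1` and compound 1 `COc1ncc(-c2ccc3ncnc(NCCN4CCCC4)c3c2)cc1C#N` differ by cyano in place of hydrogen on an aromatic carbon. In a functional assay on MCF7 cells (Homo sapiens) for antiproliferative activity, read by MTT assay, with a stated time of 72 h (on this read-out higher numbers stand for weaker inhibition and lower numbers for stronger inhibition), compound 2 gives 10100 nM, and compound 1 gives 6220 nM, a step of a 1.6-fold lower number from compound 2 to compound 1 (0.21 log units; within the scatter). Compound 3 `COc1ccc(-c2ccc3ncnc(NCCN(C)C)c3c2)cn1` and the not yet measured compound 4 `COc1ncc(-c2ccc3ncnc(NCCN(C)C)c3c2)cc1C#N` repeat the same pair on a second core. Compound 4 differs from compound 3 by cyano in place of hydrogen on an aromatic carbon, the same change as that between compound 2 and compound 1, made at a place described in the same words. The core of compound 3 differs from that of compound 2 by dimethylamino in place of pyrrolidin-1-yl on a saturated chain carbon, two bonds along the chain from a nitrogen on an aromatic ring. In this assay compound 3 gives 2970 nM, a step of a 3.4-fold lower number from compound 2 to compound 3 (0.53 log units; beyond the scatter), and the lowest of the three numbers, with compound 1 nearest and compound 2 furthest. Because the earlier instance of this change gave only a 1.6-fold lower number from compound 2 to compound 1 (0.21 log units; within the scatter), a similar step of about a 1.6-fold lower number from compound 3 to compound 4 (0.19 log units; within the scatter) is expected, lying within the scatter. Compound 4 is accordingly estimated at 1900 nM, with a likely range from 900 nM to 4500 nM.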

Compound 4, half-maximal inhibitory concentration: 3230 nM
The estimate for compound 4 lay 1.7-fold (0.23 log units) below the measured number, and the stated range covers the measured number.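

In this assay, cyano in place of hydrogen gives a 1.1-fold higher number from compound 3 to compound 4 (0.04 log units; within the scatter), so on neither core does this change move the number beyond the scatter, and the two instances agree: the same change on two cores in this assay, a 1.6-fold lower number (0.21 log units; within the scatter) from compound 2 to compound 1 and a 1.1-fold higher number (0.04 log units; within the scatter) from compound 3 to compound 4, 1.8-fold (0.25 log units) apart, within the scatter of two such steps
Dimethylamino in place of pyrrolidin-1-yl gives a 1.9-fold lower number from compound 1 to compound 4 (0.28 log units; within the scatter); this step lies within the scatter and the earlier one beyond it, yet the two do not differ beyond the scatter: the same change on two cores in this assay, a 3.4-fold lower number (0.53 log units; beyond the scatter) from compound 2 to compound 3 and a 1.9-fold lower number (0.28 log units; within the scatter) from compound 1 to compound 4, 1.8-fold (0.25 log units) apart, within the scatter of two such steps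
This shows that both changes carried over between these two cores in this one assay, but it does not show that either would carry over to any other core or cell line, nor that cyano itself improves the number.

The compounds shown leave open whether another group on that aromatic carbon, such as fluorine, an amide or a carboxylic acid, would give a larger step than cyano. They also leave open how a morpholine, a piperidine or a longer chain would compare with the two amines seen here.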